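Aryl swap from compound 1 to compound 4

The source may hold more compounds than are shown below. What is called first, only, known or untested is meant among the compounds shown, and "the series" means these compounds.

- Compound 1 `Cc1cc(=O)oc2cc(OCc3cn(-c4ccc(F)c(Cl)c4)nn3)ccc12`: > 100 ug/mL
- Compound 2 `Cc1cc(=O)oc2cc(OCc3cn(-c4ccc(Cl)cc4)nn3)ccc12`: > 100 ug/mL
- Compound 3 `COc1ccc(-n2cc(COc3ccc4c(C)cc(=O)oc4c3)nn2)c(OC)c1`: > 100 ug/mL

In an ADME assay on Huh-7 cells (Homo sapiens) for cytotoxicity, read by MTT assay, with a stated time of 72 h (on this read-out higher numbers stand for lower toxicity in this test and lower numbers for higher toxicity in this test), compound 1 gives > 100 ug/mL, which is a limit and not a number. No numerical value is available for the series, and the evidence so far is the limit of > 100 ug/mL in this assay, at which 3 of the 3 values shown sit.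

Compound 4 `Cc1cc(=O)oc2cc(OCc3cn(-c4ccccc4[N+](=O)[O-])nn3)ccc12` has yet to be measured. It differs from compound 1 at one place, with 2-nitrophenyl in place of 3-chloro-4-fluorophenyl on an aromatic nitrogen.

Among the compounds with values here, the one measured step at this place is a step that the two limits leave unreadable from compound 1 to compound 2. It gives no size to carry over, so any forecast for the new group is weakly supported. Three different aryl groups at this place have all ended at the same limit in this assay, and no step beyond the scatter is expected, though the direction cannot be excluded.

The expected step is a number no higher from compound 1 to compound 4 (the limit leaves the size open). The estimate for compound 4 is 100 ug/mL, with an expected range from 45 ug/mL to 200 ug/mL.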

Compound 4, half-maximal cytotoxic concentration: > 100 ug/mL
Compound 4 was reported as a limit; the forecaster's own chance of this, stated with the estimate: 70%; the middle value sits exactly at the limit.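

In this assay compound 4 gives > 100 ug/mL, which is a limit and not a number, so the steps to compound 4 from compound 1 and from compound 2 cannot be read. The compounds shown leave open whether changing the aryl group at this place has any effect on the read-out, as all of them end at the same point: the limit of > 100 ug/mL in this assay, at which 4 of the 4 values shown sit.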